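The source may hold more compounds than are shown below. What is called first, only, known or untested is meant among the compounds shown, and "the series" means these compounds.

In a functional assay on A549 cells (Homo sapiens) for antiproliferative activity, read by MTT assay, with a stated time of 24 h (on this read-out higher numbers stand for weaker inhibition and lower numbers for stronger inhibition), compound 1 `Cc1ccc(-c2nn(-c3ccccc3)cc2-c2nc3ccccc3[nH]2)cc1`, with hydrogen on the aromatic nitrogen, gives 4010 nM. With phenylsulfonyl in place of that hydrogen, compound 2 `Cc1ccc(-c2nn(-c3ccccc3)cc2-c2nc3ccccc3n2S(=O)(=O)c2ccccc2)cc1` gives 760 nM, which is a 5.3-fold lower number from compound 1 to compound 2 (0.72 log units; beyond the scatter). With (4-methylphenyl)sulfonyl there instead, compound 3 `Cc1ccc(-c2nn(-c3ccccc3)cc2-c2nc3ccccc3n2S(=O)(=O)c2ccc(C)cc2)cc1` gives 460 nM, which is an 8.7-fold lower number from compound 1 to compound 3 (0.94 log units; beyond the scatter). Compound 3 therefore sits with compound 2 at the low end of the three numbers, well clear of compound 1.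

Compound 4 `Cc1ccc(-c2nn(-c3ccccc3)cc2-c2nc3ccccc3n2S(=O)(=O)c2cc(C)ccc2C)cc1` alters only the aryl group on the sulfonyl sulfur: 2,5-dimethylphenyl in place of 4-methylphenyl on a sulfonyl sulfur. The large measured steps concern putting a sulfonyl group on the nitrogen, which compound 4 keeps, so they say little here. Within the data shown here, the closest precedent is the methyl added to the aryl ring, a 1.7-fold lower number from compound 2 to compound 3 (0.22 log units; within the scatter), a step within the scatter. Among the measured compounds shown here, no measured compound carries two methyl groups on this ring, so that precedent is the only guide and the range stays wide. The expected step is a 1.1-fold lower number from compound 3 to compound 4 (0.04 log units; within the scatter), which would lie within the scatter. The estimated value for compound 4 is 420 nM, with an expected range of 170 nM to 1050 nM.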

Compound 4, half-maximal inhibitory concentration: 270 nM
Compound 4: middle estimate off by 1.6-fold (0.19 log units), on the high side; the measured number falls inside the stated range.
By their numbers in this assay, from the lowest: compounds 4, 3 and 2 (each within the scatter of the next, the first and the last beyond it); then compound 1.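

In this assay, 2,5-dimethylphenyl in place of 4-methylphenyl on the sulfonyl sulfur gives a 1.7-fold lower number from compound 3 to compound 4 (0.23 log units; within the scatter) and so leaves these two compounds indistinguishable. Among these compounds, measured against the plain phenyl, however, 2,5-dimethylphenyl gives a 2.8-fold lower number from compound 2 to compound 4 (0.45 log units; beyond the scatter) and is the first change to this aryl group to clear the scatter, which the single methyl of compound 3 did not do. Among the compounds shown here, the whole (2,5-dimethylphenyl)sulfonyl group in place of hydrogen on the aromatic nitrogen gives a 15-fold lower number from compound 1 to compound 4 (1.17 log units; beyond the scatter) and is the only step here printed as large.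

On these data alone, whether a methoxy group or a chlorine on this aryl ring, or a plain methyl in place of the whole aryl group on the sulfur, would keep the number this low remains open. Nothing available explains any of these differences.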